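Moving the Thiophene Attachment Point in an Antiproliferative Series

This account rests on a few compounds, and the source may have more. Where it says the series, first, only, none or still open, it means among the compounds named here.

Measured compounds:
compound 1, `C=C(Br)C(=O)Nc1ccc2c(c1)/C(=C/c1cccs1)C(=O)N2`: 240 nM
compound 2, `C=C(Br)C(=O)Nc1ccc2c(c1)CC(=O)N2`: 4400 nM

In a functional assay on HT-29 cells (Homo sapiens) for antiproliferative activity, read by MTT assay, with a stated time of 72 h (on this read-out higher numbers stand for weaker inhibition and lower numbers for stronger inhibition), compound 1 gives 240 nM, the lowest of the two numbers recorded. Compound 2, which lacks the thiophene-bearing double bond, gives 4400 nM in this assay, a gap that lies beyond the usual scatter; no single-point comparison between these two is drawn, and the two values are simply reported as they stand.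

Compound 3, `C=C(Br)C(=O)Nc1ccc2c(c1)/C(=C/c1ccsc1)C(=O)N2`, has not yet been tested. Its difference from compound 1 is a rearrangement rather than an addition: thiophen-3-yl in place of thiophen-2-yl on a double-bonded chain carbon bound to a double-bonded ring carbon. The same atoms are present, joined differently, so the change is modest in scale.

Going by the values given here, with no measured pair of this kind to lean on, the expectation is that the step from compound 1 to compound 3 will be small, likely within the scatter, perhaps leaning slightly toward weaker inhibition. The expected step is a 1.5-fold higher number from compound 1 to compound 3 (0.16 log units; within the scatter). In this assay compound 3 is estimated at 350 nM, within a range of 120 nM to 1000 nM.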

Compound 3, half-maximal inhibitory concentration: 600 nM
Compound 3: middle estimate off by 1.7-fold (0.23 log units), on the low side, and the stated range covers the measured number.
By their numbers in this assay, from the lowest: compound 1; then compound 3; then compound 2.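

The replacement of thiophen-2-yl by thiophen-3-yl on a double-bonded chain carbon bound to a double-bonded ring carbon keeps every atom and changes only how they are joined, and in this assay it gives a 2.5-fold higher number from compound 1 to compound 3 (0.40 log units; beyond the scatter) as a modest step that still lies beyond the usual scatter. This position therefore responds to the point of attachment of the thiophene alone: the two groups match in heavy atoms, ring type and counts of hydrogen-bond donors and acceptors, yet thiophen-2-yl carries the lower number. No measurement shown here bears on the reason for this gap.

The compounds shown leave open whether the point of attachment matters in the same way for other rings, such as a furan or a pyridine joined through different ring carbons. They also leave open how a methyl group or a chlorine atom on the thiophene ring would alter the number at this position.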